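The source may report more compounds than this note shows. Statements on the series, on what has been measured and on what is new or still open speak of the compounds shown alone.

In a functional assay on the whole organism with Mus musculus as the target (a higher number here means that more compound is needed for the effect, a lower number that less compound is needed), compound 1 `CCCCC(C)NCC(N)=O` gives 640 mg/kg and compound 2 `NC(=O)CNCc1ccccc1` gives 490 mg/kg. Compound 3 `CNC(=O)CNCc1ccc(OCc2cccc(Cl)c2)cc1` gives 30.5 mg/kg, the lowest number of the three and beyond the usual scatter from both of the others, so it needs the least compound for the effect. Compound 4 `CN(CC(N)=O)Cc1ccc(OCc2cccc(Cl)c2)cc1` has the same atoms as compound 3, joined differently: (carbamoylmethyl)(methyl)amino stands in place of ((methylcarbamoyl)methyl)amino on a saturated chain carbon bound to an aromatic carbon ((carbamoylmethyl)(methyl)amino in place of ((methylcarbamoyl)methyl)amino on a saturated chain carbon bound to an aromatic carbon). Among the measured compounds shown here, no measured pair shows this kind of change, so the expectation is uncertain. The expected step, a 1.3-fold higher number from compound 3 to compound 4 (0.12 log units; within the scatter), is small, slightly upward and probably within the scatter. For compound 4 the estimate is 40 mg/kg, with an expected range from 15 mg/kg to 120 mg/kg.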

Compound 4, dose for half-maximal effect: 114 mg/kg
The estimate for compound 4 lay 2.9-fold (0.45 log units) below the measured number; the range from low to high includes it.
By their numbers in this assay, from the lowest: compound 3; then compound 4; then compounds 2 and 1 (each within the scatter of the next).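

In this assay, replacing ((methylcarbamoyl)methyl)amino with (carbamoylmethyl)(methyl)amino on a saturated chain carbon bound to an aromatic carbon gives a 3.7-fold higher number from compound 3 to compound 4 (0.57 log units; beyond the scatter) and so raises the dose needed. The two groups have the same atoms, so at this position the way those atoms are joined matters, not just which atoms are present. No measurement here explains the difference. Still open, from the compounds shown here alone, is how an ethyl group would compare with the methyl in either placement, and whether a carboxylic acid could stand in place of the amide.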